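The compounds below may be only part of what the source reports. "The series", "measured", "known", "first", "only" and "open" are said of these compounds alone.

In a functional assay on U-251 cells (Homo sapiens) for inhibition, read by sulforhodamine B assay, with a stated time of 72 h (on this read-out lower numbers stand for an effect already at smaller amounts and higher numbers for an effect only at larger amounts of compound), three compounds have been measured. Compound 1 `O=C(/C=C/c1ccc([N+](=O)[O-])o1)c1ccc(Br)cc1` gives 21400 nM, compound 2 `CCCCc1ccc(C(=O)/C=C/c2ccc([N+](=O)[O-])o2)cc1` gives 3900 nM, and compound 3 `O=C(/C=C/c1ccc([N+](=O)[O-])o1)c1ccc(C2CCCCC2)cc1` gives 4400 nM. Compound 2 thus stands at the low end of these numbers, level with compound 3, as the measured step shows: a 1.1-fold higher number from compound 2 to compound 3 (0.05 log units; within the scatter). Compound 1 stands clearly apart, with a 5.5-fold lower number from compound 1 to compound 2 (0.74 log units; beyond the scatter) and a 4.9-fold lower number from compound 1 to compound 3 (0.69 log units; beyond the scatter).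

The next structure, compound 4 `CCCCc1ccc(C(=O)/C=C/c2ccco2)cc1`, has hydrogen in place of nitro on an aromatic carbon. Among the compounds with values here, none of the measured steps touches this place. Within the data shown here, they exchange only bromo, butyl and cyclohexyl, and all three measured compounds keep the nitro, so the data offer no direct precedent for its loss. Among the measured compounds shown here, the only guide to size is the largest measured step, a 5.5-fold lower number from compound 1 to compound 2 (0.74 log units; beyond the scatter). A change of similar size toward a higher number is expected in this assay, though this remains a judgement. The estimated change is a 5.1-fold higher number from compound 2 to compound 4 (0.71 log units; beyond the scatter). For compound 4 the estimated value is 20000 nM, with an expected range from 6000 nM to 70000 nM.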

Compound 4, half-maximal effective concentration: 6400 nM
Estimate against measurement, compound 4: 3.1-fold (0.49 log units) above; measured number inside the range.
By their numbers in this assay, from the lowest: compounds 2, 3 and 4 (each within the scatter of the next); then compound 1.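

In this assay, hydrogen in place of nitro on this aromatic carbon of the five-membered aromatic ring with 1 oxygen gives a step that stays within the scatter (a 1.6-fold higher number from compound 2 to compound 4 (0.22 log units; within the scatter)). The earlier compounds shown here all kept the nitro and could say nothing about it, whereas this pair shows that, alongside butyl, compound 4 cannot be told apart from compound 2 without that group and its 3 heavy atoms. Nothing measured here gives a reason for this result.

The compounds shown leave open whether hydrogen in place of nitro reads the same way alongside bromo, as carried by compound 1, or cyclohexyl, as carried by compound 3. They also leave open how an amine, a nitrile or a carboxylic acid would read on this same aromatic carbon.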